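The source may report more compounds than this note shows. Statements on the series, on what has been measured and on what is new or still open speak of the compounds shown alone.

Working notes on the series in a functional assay on MCF7 cells (Homo sapiens) for cytotoxicity, read by sulforhodamine B assay, with a stated time of 24 h; a higher number here means a weaker inhibitor, a lower number a stronger inhibitor. Compound 1 (`N#CCC(=O)N/N=C1\C(=O)Nc2ccc(S(=O)(=O)N3CCOCC3)cc21`) gives 27700 nM and compound 2 (`O=C1Nc2ccc(S(=O)(=O)N3CCOCC3)cc2/C1=N/c1cccc(C(F)(F)F)c1`) gives 41100 nM in this read-out. Compound 3 (`N/N=C1\C(=O)Nc2ccc(S(=O)(=O)N3CCOCC3)cc21`) gives 46800 nM and so stands level with the other two. The steps into compound 3 are a 1.1-fold higher number from compound 2 to compound 3 (0.06 log units; within the scatter) and a 1.7-fold higher number from compound 1 to compound 3 (0.23 log units; within the scatter) and neither separates it from its neighbours.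

The move to compound 4 (`O=C1Nc2ccc(S(=O)(=O)N3CCOCC3)cc2/C1=N/c1ccc(C(=O)O)cc1`) is 4-carboxyphenyl in place of amino on a double-bonded nitrogen. Two measured steps change the group on that same nitrogen. One is a 1.5-fold higher number from compound 1 to compound 2 (0.17 log units; within the scatter) and the other is a 1.1-fold higher number from compound 2 to compound 3 (0.06 log units; within the scatter) and both stay within the scatter. Among the compounds with values here, compound 2 already carries a 3-(trifluoromethyl)phenyl at this place, yet no measured compound carries 4-carboxyphenyl, and that leaves the range wide.

No step beyond the scatter is therefore expected in this assay, and no direction can be argued from these three compounds. The expected step is a 1.2-fold lower number from compound 3 to compound 4 (0.09 log units; within the scatter) in size. For compound 4 the estimated value is 38000 nM with an expected range from 15000 nM to 90000 nM as the working figure.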

Compound 4, half-maximal inhibitory concentration: 26700 nM
Beside the measured number, compound 4's estimate is 1.4-fold (0.15 log units) above it; the measured number falls inside the stated range.
By their numbers in this assay, from the lowest: compounds 4, 1, 2 and 3 (each within the scatter of the next).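

In this assay the place on the double-bonded nitrogen also accepts 4-carboxyphenyl, and all three new steps stay within the scatter: against amino (a 1.8-fold lower number from compound 3 to compound 4 (0.24 log units; within the scatter)), against 3-(trifluoromethyl)phenyl (a 1.5-fold lower number from compound 2 to compound 4 (0.19 log units; within the scatter)) and against ((cyanomethyl)carbonyl)amino (a 1.0-fold lower number from compound 1 to compound 4 (0.02 log units; within the scatter)). The change from amino brings in 9 heavy atoms and a six-membered aromatic ring in place of 1 heavy atom, and even this does not separate the compounds, so the four groups at this place now stand level in this read-out. Nothing in hand gives a reason for this flat picture.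

The compounds shown leave open whether a 4-aminophenyl, a 4-methoxyphenyl or a longer alkyl chain on this nitrogen would give a step beyond the scatter, and whether the carboxylic acid of compound 4 would read the same as its methyl ester. All four compounds share the same core, so what a change elsewhere on that core would do in this assay cannot be read from them.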